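Working notes: compound 3 to compound 4

The compounds below may be only part of what the source reports. "The series", "measured", "known", "first", "only" and "open" are said of these compounds alone.

Measured in an in vitro ADME assay on microsomes from liver (Homo sapiens) for metabolic stability; on this read-out lower numbers stand for slow clearance and higher numbers for fast clearance:
- compound 1 `Cc1cnc(NC(=O)c2cc(Oc3ccc(C(=O)N(C)C)cc3)c3cn(C)nc3c2)cn1`: 12.3 mL/min/kg
- compound 2 `CCS(=O)(=O)c1ccc(Oc2cc(C(=O)Nc3cnc(C)cn3)cc3nn(C)cc23)cc1`: < 8 mL/min/kg
- compound 3 `Cc1cnc(NC(=O)c2cc(Oc3ccc(S(=O)(=O)N(C)C)cc3)c3cn(C)nc3c2)cn1`: < 8 mL/min/kg

Compound 3 stands at < 8 mL/min/kg, which is a limit and not a number. Compound 2 also gives a limit, < 8 mL/min/kg. Only compound 1 has a measured number, 12.3 mL/min/kg. Among the measured compounds shown here, the series so far is crowded at the end of the scale: the limit of < 8 mL/min/kg in this assay, at which 2 of the 3 values shown sit.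

Compound 4 `CNS(=O)(=O)c1ccc(Oc2cc(C(=O)Nc3cnc(C)cn3)cc3nn(C)cc23)cc1` is the next structure, and the change is hydrogen in place of methyl on a sulfonamide nitrogen. In words, this is hydrogen in place of methyl on a sulfonamide nitrogen.

The measured steps bear on this change only indirectly, since none of them alters a group on that nitrogen. Replacing dimethylcarbamoyl gives an at least 1.5-fold lower number from compound 1 to compound 2 (0.18 log units; that floor lies within the scatter) and an at least 1.5-fold lower number from compound 1 to compound 3 (0.18 log units; that floor lies within the scatter). Placing dimethylamino where ethyl stood on the sulfonyl sulfur gives a step that the two limits leave unreadable from compound 2 to compound 3. None of these steps points to a large shift, so no step beyond the scatter is expected, in either direction.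

The expected step is a step that the limit leaves unreadable from compound 3 to compound 4. A report as a limit is also expected to be more likely than not. For compound 4 the estimated clearance is 7 mL/min/kg, with an expected range of 4 mL/min/kg to 13 mL/min/kg.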

Compound 4, clearance: < 8.6 mL/min/kg
Compound 4 was reported as a limit (the forecaster's own chance of this, stated with the estimate: 60%); the middle value lies beyond the limit too.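

In this assay compound 4 gives < 8.6 mL/min/kg, which is a limit and not a number, and it places methylsulfamoyl at the low end of the scale with a limit of its own: the limit of < 8.6 mL/min/kg in this assay, at which 1 of the 4 values shown sits. Set against the dimethylcarbamoyl group of compound 1, methylsulfamoyl gives an at least 1.4-fold lower number from compound 1 to compound 4 (0.15 log units; that floor lies within the scatter), so this comparison alone does not separate the two groups. The steps to compound 4 from compound 3 and from compound 2 cannot be read, so hydrogen in place of methyl on the sulfonamide nitrogen shows only that this nitrogen can carry a hydrogen with the result still reported as a limit, and it gives no size for any effect of the change.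

As far as these compounds go, the size of any difference among compound 2, compound 3 and compound 4 remains open, as none of them has a number in this assay. Also open, from the compounds shown here alone, is how the read-out would respond to a longer chain on the sulfonamide nitrogen, such as propyl, or to a morpholine ring in place of methylamino.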